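This account rests on a few compounds, and the source may have more. Where it says the series, first, only, none or still open, it means among the compounds named here.

Measured compounds:
Compound 1 `Cc1ccc(CS/C(=C/c2ccc(C)s2)C(=O)c2ccc(Cl)cc2)cc1`, which in a functional assay on DU-145 cells (Homo sapiens) for inhibition, read by trypan blue exclusion, with a stated time of 96 h (a lower number here means a stronger inhibitor of growth, a higher number a weaker inhibitor of growth), gives 50000 nM.
Compound 2 `Cc1ccc(S/C(=C/c2c(F)c(F)c(F)c(F)c2F)C(=O)c2ccc(Cl)cc2)cc1`, which in this assay gives 25000 nM.

Among these two numbers compound 1 has the higher one, but the gap to compound 2 lies within the scatter of this kind of measurement, so the two cannot be told apart. Both sit at weak inhibition.

Compound 3 `COc1ccccc1/C=C(/SCc1ccc(C)cc1)C(=O)c1ccc(Cl)cc1` has not yet been measured. It differs from compound 1 in one place: 2-methoxyphenyl in place of 5-methylthiophen-2-yl on a double-bonded chain carbon bound to a double-bonded chain carbon. The rest of the shared core is kept unchanged.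

Among the measured compounds shown here, no step between measured compounds is known here, so nothing measured shows how such a swap moves the number. Both compounds already measured sit close together at weak inhibition, and there is no ground to expect a step in this assay beyond the scatter in either direction. Compound 3 is therefore expected to land near 40000 nM, between 15000 nM and 100000 nM, an estimated step of a 1.3-fold lower number from compound 1 to compound 3 (0.10 log units; within the scatter).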

Compound 3, concentration for 50% growth inhibition: 10000 nM
The estimate for compound 3 lay 4.0-fold (0.60 log units) above the measured number; measured number outside the range, below it.
By their numbers in this assay, from the lowest: compound 3; then compounds 2 and 1 (each within the scatter of the next).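

Among the compounds shown here, this place, on a double-bonded chain carbon bound to a double-bonded chain carbon, responds to the group it carries: in this assay replacing 5-methylthiophen-2-yl with 2-methoxyphenyl gives a 5.0-fold lower number from compound 1 to compound 3 (0.70 log units; beyond the scatter) and this step lies beyond the scatter, whereas the two earlier compounds offered no step in one place at all. The step is modest and rests on a single pair, so it shows sensitivity at this place and no general rule. Nothing measured here explains why the number moved.

On these data alone, it remains open which part of the entering group counts, the ring of carbon only or its methoxy group. As far as these compounds go, a plain phenyl, or a ring carrying an amine or a carboxylic acid at this place, would help separate these, and whether the gain holds with other groups on the sulfur also remains open.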